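Shifting One Methoxy Group Between Two Ring Positions

The source may hold more compounds than are shown below. What is called first, only, known or untested is meant among the compounds shown, and "the series" means these compounds.

Of the compounds shown here, three built on the same core have been tested in a functional assay on MDA-MB-231 cells (Homo sapiens) for antiproliferative activity, read by CCK-8 assay, with a stated time of 72 h; a lower number here means a stronger inhibitor, a higher number a weaker inhibitor. Compound 1 `COc1ccc(C(=O)Nc2ccc(C(=O)/C=C/c3nc(C)c(C)nc3C)cc2)cc1OC` gives 3360 nM. Compound 2 `Cc1nc(C)c(/C=C/C(=O)c2ccc(NC(=O)c3ccccc3)cc2)nc1C` gives 1840 nM, and compound 3 `Cc1ccc(C(=O)Nc2ccc(C(=O)/C=C/c3nc(C)c(C)nc3C)cc2)cc1` gives 1780 nM. Compound 1 carries the highest of these three numbers, yet the steps of a 1.8-fold lower number from compound 1 to compound 2 (0.26 log units; within the scatter) and a 1.9-fold lower number from compound 1 to compound 3 (0.28 log units; within the scatter) both fall within the scatter, so none of the three can be called the stronger or weaker inhibitor on this evidence.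

Compound 4 `COc1cc(OC)cc(C(=O)Nc2ccc(C(=O)/C=C/c3nc(C)c(C)nc3C)cc2)c1` has not yet been measured. It differs from compound 1 in a single place: 3,5-dimethoxyphenyl in place of 3,4-dimethoxyphenyl on a carbonyl carbon. The same atoms are present, joined differently.

The measured steps that bear on this are the two that altered the same group: a 1.8-fold lower number from compound 1 to compound 2 (0.26 log units; within the scatter) stripped away both methoxy groups, and a 1.9-fold lower number from compound 1 to compound 3 (0.28 log units; within the scatter) exchanged them for one methyl. Neither moved the number beyond the scatter. Rearranging the two methoxy groups keeps compound 4 closer to compound 1 than either of those changes, so no step beyond the scatter is expected, at most a slight drift toward a lower number. Compound 4 is therefore estimated at 2600 nM, with a range of 1200 nM to 5600 nM. The expected step is a 1.3-fold lower number from compound 1 to compound 4 (0.11 log units; within the scatter), which is expected to remain within the scatter.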

Compound 4, half-maximal inhibitory concentration: 11600 nM
Estimate against measurement, compound 4: 4.5-fold (0.65 log units) below, outside the stated range (above it).
By their numbers in this assay, from the lowest: compounds 3, 2 and 1 (each within the scatter of the next); then compound 4.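

Among these compounds, at this place on the carbonyl carbon, the arrangement of the two methoxy groups counts for more than anything the earlier compounds showed: the atoms stay the same, yet in this assay the change to 3,5-dimethoxyphenyl gives a 3.5-fold higher number from compound 1 to compound 4 (0.54 log units; beyond the scatter) while removing both groups or exchanging them for one methyl had stayed within the scatter. The 3,5-dimethoxyphenyl group also separates clearly from the simpler rings, with a 6.5-fold higher number from compound 3 to compound 4 (0.81 log units; beyond the scatter) and a 6.3-fold higher number from compound 2 to compound 4 (0.80 log units; beyond the scatter) so that compound 4 is the weakest inhibitor of the four. Nothing measured here explains why this rearrangement raises the number.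

On these data alone, it remains open whether the rise belongs to the pair of methoxy groups or would persist with only one of them. Nor do these compounds show what chlorine atoms or hydroxyl groups would do in their place.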